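Swapping a cyanophenyl for a benzothiazolyl on a flavone ether

A few compounds are considered here, and "the series" means these few. Any claim that something is new, unique, unknown or untested is made for them only; others in the source may bear on it.

Measured compounds:
- compound 1, `CCN(CC)CCCOc1c(OCc2ccccc2)cc(O)c2c(=O)cc(-c3ccccc3)oc12`, 3210 nM
- compound 2, `CN1CCN(CCCCOc2c(OCc3ccc(C#N)cc3)cc(O)c3c(=O)cc(-c4ccccc4)oc23)CC1`, 2420 nM

Of the compounds shown here, two have been tested in a functional assay on MCF7 cells (Homo sapiens) for cytotoxicity, read by MTT assay, with a stated time of 72 h; a higher number here means a weaker inhibitor, a lower number a stronger inhibitor. Compound 1 gives 3210 nM, and compound 2 gives 2420 nM. The two numbers lie close together, within the usual scatter of repeated measurements, so neither compound can be called the stronger or weaker inhibitor on this evidence; compound 2 simply carries the smaller figure.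

Compound 3, `CN1CCN(CCCCOc2c(OCc3nc4ccccc4s3)cc(O)c3c(=O)cc(-c4ccccc4)oc23)CC1`, has not yet been measured in this assay. It differs from compound 2 in one place: 1,3-benzothiazol-2-yl in place of 4-cyanophenyl on a saturated chain carbon bound to an oxygen on an aromatic ring. Among the compounds with values here, nothing in the two measured compounds shows how such a replacement moves the number, since compound 1 and compound 2 differ in several places at once and no single-change pair exists.

The expectation is therefore cautious: a small step, not clearly beyond the scatter, in either direction. For compound 3 the estimated value in this assay is 2000 nM, with a plausible range from 800 nM to 5000 nM. This expected result corresponds to a step of a 1.2-fold lower number from compound 2 to compound 3 (0.08 log units; within the scatter).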

Compound 3, half-maximal inhibitory concentration: 4850 nM
For compound 3 the middle estimate is 2.4-fold (0.38 log units) below the measured one; the range from low to high includes it.
By their numbers in this assay, from the lowest: compounds 2, 1 and 3 (each within the scatter of the next).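

Within the data shown here, this is the first pair here that differs in one place only, so the swap of 4-cyanophenyl for 1,3-benzothiazol-2-yl on a saturated chain carbon bound to an oxygen on an aromatic ring can now be read on its own in this assay without other changes mixed in. The outcome is a 2.0-fold higher number from compound 2 to compound 3 (0.30 log units; within the scatter) and stays within the usual scatter of repeated measurements, so at this position a single six-membered aromatic ring bearing a nitrile and a fused pair of rings containing sulfur and nitrogen cannot be told apart by this measurement. Nothing measured here offers an explanation for this result.

On these data alone, it remains open whether a quite different group at this place, such as a pyridin-2-yl ring or a carboxylic acid, would give a step beyond the scatter. Also open, as far as these compounds go, is whether the same swap would read alike with the diethylamino chain of compound 1 in place of the methylpiperazine chain shared by compound 2 and compound 3.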